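The source may hold more compounds than are shown below. What is called first, only, known or untested is meant among the compounds shown, and "the series" means these compounds.

Measured so far:
- compound 1 `COc1cc(-c2nc3cc(/C=C4\SC(=O)N(CC(=O)N5CCOCC5)C4=O)ccc3[nH]2)cc(OC)c1OC`: 5940 nM
- compound 2 `COc1cc(-c2nc3cc(/C=C4\SC(=O)N(Cc5ccccc5)C4=O)ccc3[nH]2)cc(OC)c1OC`: 2500 nM

In a functional assay on PC-3 cells (Homo sapiens) for inhibition, read by MTT assay, with a stated time of 48 h (on this read-out higher numbers stand for weaker inhibition and lower numbers for stronger inhibition), compound 1 gives 5940 nM and compound 2 gives 2500 nM. Within the data shown here, compound 2 stands lowest of the two numbers; its only neighbour is compound 1, reached by a 2.4-fold lower number from compound 1 to compound 2 (0.38 log units; beyond the scatter), a modest step.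

Compound 3 `COc1cc(CN2C(=O)S/C(=C\c3ccc4[nH]c(-c5cc(OC)c(OC)c(OC)c5)nc4c3)C2=O)cc(OC)c1OC` is not yet measured. Against compound 2 the change is 3,4,5-trimethoxyphenyl in place of phenyl on a saturated chain carbon bound to an amide-type nitrogen in a ring. Among the measured compounds shown here, the single measured step, a 2.4-fold lower number from compound 1 to compound 2 (0.38 log units; beyond the scatter), swaps the whole group on that chain carbon and so bears only loosely on a change that keeps the phenyl and adds methoxy groups to it; no measured pair shows the effect of those substituents at this place. With nothing closer to go on, the expected step is no change at the digits printed from compound 2 to compound 3 (within the scatter), that is, not beyond the scatter in either direction. Compound 3 is therefore expected at 2500 nM, with a range of 800 nM to 8000 nM.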

Compound 3, half-maximal inhibitory concentration: 10200 nM
Compound 3: middle estimate off by 4.1-fold (0.61 log units), on the low side; the measured number lies above the stated range.
By their numbers in this assay, from the lowest: compound 2; then compounds 1 and 3 (each within the scatter of the next).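

In this assay, the phenyl on the saturated chain carbon bound to an amide-type nitrogen in a ring does not tolerate free substitution: 3,4,5-trimethoxyphenyl in its place gives a 4.1-fold higher number from compound 2 to compound 3 (0.61 log units; beyond the scatter) and so reverses the direction of the earlier step towards phenyl. Set against the (morpholin-4-yl)carbonyl group, 3,4,5-trimethoxyphenyl gives a 1.7-fold higher number from compound 1 to compound 3 (0.23 log units; within the scatter), so an aromatic ring at this place does not by itself set a compound apart from compound 1. No measurement at hand accounts for the step between phenyl and 3,4,5-trimethoxyphenyl.

As far as these compounds go, whether a single methoxy group on the phenyl would produce the same step remains open. Also open, from the compounds shown here alone, is how a pyridine ring, a carboxylic acid or a longer chain would read at this place.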